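A few compounds are considered here, and "the series" means these few. Any claim that something is new, unique, unknown or untested is made for them only; others in the source may bear on it.

In a functional assay on MCF7 cells (Homo sapiens) for cytotoxicity, read by MTT assay, with a stated time of 96 h (on this read-out lower numbers stand for stronger inhibition and higher numbers for weaker inhibition), compound 1 (`COc1ccc(-c2cn(-c3ccccc3)cc2C(=O)c2cc(OC)c(OC)c(OC)c2)cc1`) gives 70 nM and compound 2 (`COc1cc(C(=O)c2cn(-c3cccc(C)c3)cc2-c2ccccc2F)cc(OC)c1OC`) gives 190 nM, the higher of the two numbers, with a gap beyond the scatter. Compound 3 (`COc1cc(C(=O)c2cn(-c3cccc(C)c3)cc2-c2ccc([N+](=O)[O-])cc2)cc(OC)c1OC`) keeps the 3-methylphenyl group of compound 2 and the shared core, and carries 4-nitrophenyl in place of 2-fluorophenyl on an aromatic carbon. The site lies two ring bonds from the ring nitrogen. Going by the values given here, no measured pair isolates this change, and the two measured compounds differ in more than one place, so the expectation is loose. A modest rise in the number, meaning weaker inhibition, is expected in this assay, near the edge of the scatter. The estimated move is a 2.1-fold higher number from compound 2 to compound 3 (0.32 log units; beyond the scatter) on this read-out. Compound 3 is expected at 400 nM (estimated range 100 nM to 1500 nM).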

Compound 3, half-maximal inhibitory concentration: 780 nM
Estimate against measurement, compound 3: 2.0-fold (0.29 log units) below; low and high end bracket the measured number.
By their numbers in this assay, from the lowest: compound 1; then compound 2; then compound 3.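

In this assay, 4-nitrophenyl in place of 2-fluorophenyl, on the aromatic carbon two ring bonds from the ring nitrogen and with the 3-methylphenyl group held constant, gives a 4.1-fold higher number from compound 2 to compound 3 (0.61 log units; beyond the scatter). Going by these compounds alone, this is the first single-place step, and it shows that inhibition at this position depends on which substituted phenyl group is attached, with weaker inhibition for the 4-nitrophenyl group. No measurement shown here accounts for the step.

The step changes both the substituent and its place on the phenyl ring, so the compounds shown do not separate these two changes; 4-fluorophenyl or 2-nitrophenyl would do so. From the compounds shown here alone, how an amine or a carboxylic acid on that phenyl ring would read in this assay also remains open.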